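A Second Fluorine on the Phenyl Ring of Compound 3

The source may hold more compounds than are shown below. What is called first, only, known or untested is meant among the compounds shown, and "the series" means these compounds.

Compound 3 `N#Cc1c(N2CCC(c3ccccc3F)CC2)ccn(CC2CC2)c1=O` gives 282% in a functional assay on CHO cells for positive allosteric modulation of metabotropic glutamate receptor 2 (Homo sapiens), with a stated time of 30 min (a higher number here means a larger maximal response, a lower number a smaller maximal response), the highest of the three measured numbers. Nearest stands compound 2 `N#Cc1c(N2CCC(c3ccccc3)CC2)ccn(CC2CCC2)c1=O`, which gives 269% in this assay, a number beyond the scatter below compound 3, and compound 1 `CC(C)CCn1ccc(CCc2ccccc2)c(C#N)c1=O` gives 168% in this assay, far below both. Compound 4 `N#Cc1c(N2CCC(c3ccc(F)cc3F)CC2)ccn(CC2CC2)c1=O` is not yet measured. It differs from compound 3 in one place: fluoro in place of hydrogen on an aromatic carbon. Among the compounds with values here, no pair of measured compounds differing in one place is at hand, so the size of this step rests on the change alone. The step of a number 7 percentage points lower from compound 3 to compound 4 (within the scatter) is expected to be small, none beyond the scatter, because compound 3 already gives 282% in this assay. Compound 4 is expected to give 275% in this assay, within 210% to 340%.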

Compound 4, largest response reached (Emax), in percent of the reference or control that the assay uses: 272%
For compound 4 the middle estimate is 3 percentage points above the measured one, within the range that was stated.
By their numbers in this assay, from the lowest: compound 1; then compounds 2, 4 and 3 (each within the scatter of the next, the first and the last beyond it).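

In this assay, within the data shown here, going from 2-fluorophenyl to 2,4-difluorophenyl gives a number 10 percentage points lower from compound 3 to compound 4 (within the scatter), the only step here between measured compounds that differ in one place. This place on the ring, para to a large group, thus takes a fluoro group with no change beyond the scatter. No measured property bears on this result, and the data give no explanation for it.

On these data alone, whether a methoxy group, a trifluoromethyl group or an amine at this same place would also stay within the scatter remains open. Also open, as far as these compounds go, is whether fluoro at this place would give a similar step in compound 2, which carries a different group on the ring nitrogen.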